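Guanidine for aminopropylamino at the chain end

This account rests on a few compounds, and the source may have more. Where it says the series, first, only, none or still open, it means among the compounds named here.

Compound 3, `CC(C)=CCNC(=N)NCCCNCCCN`, gives 1210 nM in an assay on isolated protein for inhibition of polyamine oxidase 1 (Zea mays), read by spectrophotometry, using a Dixon plot, at pH 6.5; on this read-out lower numbers stand for stronger inhibition and higher numbers for weaker inhibition. Of the three numbers measured, that is the second highest: compound 2, `CC(C)=CCNC(=N)NCCCCNC(=N)NCC=C(C)C`, gives 1500 nM, a value within the usual scatter of compound 3, while compound 1, `CC(C)=CCNC(=N)NCCCCCCN`, gives 22 nM, far lower. Among the measured compounds shown here, the one step measured in one place, a 55-fold higher number from compound 1 to compound 3 (1.74 log units; beyond the scatter), shows that the end of the chain matters greatly here.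

Compound 4, `CC(C)=CCNC(=N)NCCCCNC(=N)N`, differs from compound 3 by a group of 5 heavy atoms (2 carbon, 3 nitrogen; no ring) in place of a group of 5 heavy atoms (3 carbon, 2 nitrogen; no ring), on a saturated chain carbon, three bonds along the chain from an amine nitrogen. For the measured compounds named here, no measured step swaps these two groups, so the only guide is that changes at this chain end can be large, as the step from compound 1 to compound 3 was, while compound 2 and compound 3 show that two different ends can also land close together. The expected step of a 1.3-fold lower number from compound 3 to compound 4 (0.13 log units; within the scatter) is therefore not beyond the scatter, with wide uncertainty. Compound 4 is estimated at 900 nM, within 150 nM to 5000 nM.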

Compound 4, inhibition constant: 700 nM
Compound 4: middle estimate off by 1.3-fold (0.11 log units), on the high side; the range from low to high includes it.
By their numbers in this assay, from the lowest: compound 1; then compounds 4, 3 and 2 (each within the scatter of the next, the first and the last beyond it).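

Putting a guanidine in place of (3-aminopropyl)amino at this chain end leaves the number in this assay within the scatter (a 1.7-fold lower number from compound 3 to compound 4 (0.24 log units; within the scatter)), so the two groups cannot be told apart here. Hydrogen in place of 3-methylbut-2-en-1-yl on an amine nitrogen gives a modest step just beyond the scatter (a 2.1-fold lower number from compound 2 to compound 4 (0.33 log units; beyond the scatter)), so the second 3-methylbut-2-en-1-yl group is not needed for the binding seen at this level. Even so, the guanidine-ended chain remains far weaker than the plain amine-ended chain (a 32-fold higher number from compound 1 to compound 4 (1.50 log units; beyond the scatter)), so a guanidine does not stand in for that end.

From the compounds shown here alone, whether a carboxylic acid, a hydroxyl or a longer chain at this end would come close to compound 1 or stay near compound 4 remains open. Nothing measured here explains why these chain ends differ.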